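From furan-2-yl to 1,3-thiazol-2-yl on the shared core

This account rests on a few compounds, and the source may have more. Where it says the series, first, only, none or still open, it means among the compounds named here.

- compound 1 `COC1=C(C)C(=O)/C(=C(O)/C=C/c2ccc(F)cc2)C(=O)C1(C)C` gives 3.7 ug/mL
- compound 2 `COC1=C(C)C(=O)/C(=C(O)/C=C/c2ccco2)C(=O)C1(C)C` gives 9.9 ug/mL

For the measured compounds named here, in a functional assay on KB cells (Homo sapiens) for cytotoxicity (on this read-out higher numbers stand for an effect only at larger amounts of compound and lower numbers for an effect already at smaller amounts), compound 2 stands at the higher of the two numbers, 9.9 ug/mL, and the only other measured compound, compound 1, gives 3.7 ug/mL.

Compound 3 `COC1=C(C)C(=O)/C(=C(O)/C=C/c2nccs2)C(=O)C1(C)C` keeps the shared core of compound 2 and changes one group: 1,3-thiazol-2-yl in place of furan-2-yl on a double-bonded chain carbon bound to a double-bonded chain carbon. Going by the values given here, the exchange lies on a double-bonded chain carbon bound to a double-bonded chain carbon, the same place that changes in the one measured step. That step runs a 2.7-fold higher number from compound 1 to compound 2 (0.43 log units; beyond the scatter), modest in size and beyond the scatter. It replaces 4-fluorophenyl with furan-2-yl, so it shows that the number in this assay can move with the group at this place. Among the compounds with values here, it gives no direction for one five-membered aromatic ring replacing another, and no measured compound carries 1,3-thiazol-2-yl. A step no larger than the measured one is therefore expected, most likely within the scatter and with no firm direction. The estimated step is a 1.3-fold lower number from compound 2 to compound 3 (0.12 log units; within the scatter). For compound 3 the estimated value is 7.5 ug/mL, with an expected range from 3 ug/mL to 19 ug/mL.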

Compound 3, concentration for half-maximal effect: 4.3 ug/mL
Compound 3: middle estimate off by 1.7-fold (0.24 log units), on the high side, within the range that was stated.
By their numbers in this assay, from the lowest: compounds 1 and 3 (each within the scatter of the next); then compound 2.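

In this assay, exchanging one five-membered aromatic ring for another at this place is enough to move the number beyond the scatter (a 2.3-fold lower number from compound 2 to compound 3 (0.36 log units; beyond the scatter)), which the earlier comparison of 4-fluorophenyl with furan-2-yl could not show. The 1,3-thiazol-2-yl and 4-fluorophenyl groups give numbers that stand within the scatter of each other (a 1.2-fold higher number from compound 1 to compound 3 (0.07 log units; within the scatter)), so among these three groups on a double-bonded chain carbon bound to a double-bonded chain carbon, furan-2-yl alone stands apart, at the higher number. No measurement bears on why the number follows the group in this way.

Going by these compounds, three aromatic groups on one shared core give no trend, and whether the gap between furan-2-yl and 1,3-thiazol-2-yl would persist on a different core remains open. On these data alone, it is also open how the number would respond to a non-aromatic group at this place, such as an amine, a carboxylic acid or a longer saturated chain in place of the 2-(1,3-thiazol-2-yl)ethenyl group.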